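The source may hold more compounds than are shown below. What is called first, only, known or untested is meant among the compounds shown, and "the series" means these compounds.

In a functional assay on HCT-116 cells (Homo sapiens) for antiproliferative activity, read by MTT assay, with a stated time of 72 h (a lower number here means a stronger inhibitor, a higher number a weaker inhibitor), compound 1 `O=C(CCc1cccc2c1B(O)OC2)Nc1ccccc1` gives 350 nM, while compound 2 `O=C(CCc1cccc2c1B(O)OC2)Nc1cccc(I)c1` gives 2300 nM, the higher of the two numbers. Compound 3 `CC(C)c1cccc(NC(=O)CCc2cccc3c2B(O)OC3)c1` differs from compound 2 at one place: isopropyl in place of iodo on an aromatic carbon. Isopropyl stands in place of iodo on an aromatic carbon, meta to a large group. Among the measured compounds shown here, only one measured step bears on this change, the modest 6.6-fold higher number from compound 1 to compound 2 (0.82 log units; beyond the scatter), which comes from iodo in place of hydrogen on an aromatic carbon. For the measured compounds named here, no measured compound shows how any other group compares with iodo, so that step gives only a rough guide. With that single step from compound 1 as the guide, compound 3 is expected to stay close to compound 2 in this assay, with no shift beyond the scatter. The expected change is a 1.4-fold lower number from compound 2 to compound 3 (0.13 log units; within the scatter). The estimated value for compound 3 is 1700 nM, within a range of 600 nM to 4800 nM.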

Compound 3, half-maximal inhibitory concentration: 1600 nM
Beside the measured number, compound 3's estimate is 1.1-fold (0.03 log units) above it, and the stated range covers the measured number.
By their numbers in this assay, from the lowest: compound 1; then compounds 3 and 2 (each within the scatter of the next).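

In this assay, isopropyl in place of iodo gives a 1.4-fold lower number from compound 2 to compound 3 (0.16 log units; within the scatter), so at this place, meta to a large group, a group of three carbon atoms and a single iodine atom read alike. Isopropyl in place of hydrogen gives a 4.6-fold higher number from compound 1 to compound 3 (0.66 log units; beyond the scatter), which shows that the higher number seen with iodo is not confined to that one group, since both substituted compounds lie on the same side of compound 1. Nothing available explains why these numbers fall as they do.

Going by these compounds, whether an amine, a carboxylic acid or a methoxy group at this place would also give a higher number than compound 1 remains open. So does whether a group as small as fluoro would already separate from compound 1 by more than the scatter.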